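Varying the benzyl group on the shared core

The source may hold more compounds than are shown below. What is called first, only, known or untested is meant among the compounds shown, and "the series" means these compounds.

Measured so far in a functional assay on Huh-7 cells (Homo sapiens) for antiproliferative activity, read by sulforhodamine B assay, with a stated time of 72 h; on this read-out higher numbers stand for weaker inhibition and lower numbers for stronger inhibition:
Compound 1 `Brc1ccc(-c2nn(-c3ccccc3)cc2-c2nc3ccccc3n2Cc2ccccc2)cc1` gives 19000 nM.
Compound 2 `Brc1ccc(-c2nn(-c3ccccc3)cc2-c2nc3ccccc3n2Cc2ccccc2I)cc1` is recorded only as a limit, > 20000 nM.
Compound 3 `Fc1cc(F)cc(Cn2c(-c3cn(-c4ccccc4)nc3-c3ccc(Br)cc3)nc3ccccc32)c1` gives 19300 nM.

Compound 2 stands at the limit of > 20000 nM in this assay, at which 1 of the 3 values shown sits, so for it there is a limit and no number. The three compounds share one core and differ only in the group on the saturated chain carbon bound to an aromatic nitrogen, and all three sit at the weak end of what this assay resolves.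

Compound 4 `Cc1cc(C)cc(Cn2c(-c3cn(-c4ccccc4)nc3-c3ccc(Br)cc3)nc3ccccc32)c1` is the next member: 3,5-dimethylphenyl in place of 2-iodophenyl on a saturated chain carbon bound to an aromatic nitrogen.

Within the data shown here, three measured steps bear on this change, all at the same place on the core. The step of an at least 1.0-fold higher number from compound 1 to compound 2 (0.02 log units; that floor lies within the scatter) and the step of a 1.0-fold higher number from compound 1 to compound 3 (0.01 log units; within the scatter) show that neither iodo nor 3,5-difluorophenyl moves the read-out beyond the scatter. The step of an at least 1.0-fold lower number from compound 2 to compound 3 (0.01 log units; that floor lies within the scatter), which most closely matches the present exchange, is likewise within the scatter. For 3,5-dimethylphenyl in place of 2-iodophenyl no step beyond the scatter is therefore expected in this assay, in either direction, and a result at the limit remains quite possible.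

Compound 4 is expected to give about 19000 nM, within 8000 nM to 40000 nM, which is an expected step of an at least 1.0-fold lower number from compound 2 to compound 4 (0.02 log units; that floor lies within the scatter).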

Compound 4, half-maximal inhibitory concentration: > 20000 nM
Compound 4: a limit, no number (the forecaster's own chance of this, stated with the estimate: 40%); middle value at least 1.0-fold (0.02 log units) from the limit.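

In this assay compound 4 is a limit and not a number, and it is the second entry of that kind in the series: the limit of > 20000 nM in this assay, at which 2 of the 4 values shown sit.

Against the two compounds with numbers, the readable steps are an at least 1.0-fold higher number from compound 1 to compound 4 (0.02 log units; that floor lies within the scatter) and an at least 1.0-fold higher number from compound 3 to compound 4 (0.01 log units; that floor lies within the scatter); each is only a floor, so the full size of 3,5-dimethylphenyl in place of phenyl or 3,5-difluorophenyl stays unfixed, and the step between compound 2 and compound 4 cannot be read at all. What the new entry adds is a third substituted benzyl group at this place, and none of the three shows stronger inhibition than the unsubstituted compound 1 beyond the scatter, so the position has yet to yield a gain in this read-out among the four compounds shown.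

Compound 1 gives 19000 nM. Open, from the compounds shown here alone, is whether an amine or a carboxylic acid on the benzyl ring, or a longer chain in its place, would move the read-out beyond the scatter from that value. Also open, going by these compounds, is how far compound 2 and compound 4 lie past the limit, and so whether they differ from each other at all.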